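This account rests on a few compounds, and the source may have more. Where it says the series, first, only, none or still open, it means among the compounds named here.

Series notes, antagonism at the serotonin receptor.

Of the compounds shown here, two have numbers so far. Compound 1, `Cc1[nH]cnc1CN1CCN(c2ccccc2)C1=O`, gives in a functional assay (Cavia porcellus) for antagonist activity at Serotonin 3 (5-HT3) receptor (Homo sapiens) (a lower number here means a stronger inhibitor, a higher number a weaker inhibitor), a value of 26.9 nM. Compound 2, `CSc1cccc(N2CCN(Cc3nc[nH]c3C)C2=O)c1`, gives in this assay a value of 120 nM. Going by the values given here, the single measured step is a 4.5-fold higher number from compound 1 to compound 2 (0.65 log units; beyond the scatter); compound 2 therefore holds the highest of the two numbers, with compound 1 as its only neighbour.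

The next compound, compound 3, `Cc1[nH]cnc1CN1CCN(c2cccc([N+](=O)[O-])c2)C1=O`, is not yet measured. Against compound 2 the change is nitro in place of methylsulfanyl on an aromatic carbon. Among the compounds with values here, no measured step exchanges one substituent on that ring for another; the only step that bears on the position is the one from hydrogen to methylsulfanyl, a 4.5-fold higher number from compound 1 to compound 2 (0.65 log units; beyond the scatter), which is modest and runs toward a higher number. Compound 3 keeps a substituent at the same place, so the number is expected to stay near that of compound 2, with a step of a 1.3-fold lower number from compound 2 to compound 3 (0.12 log units; within the scatter) not expected to go beyond the scatter. For compound 3 the estimate in this assay is 90 nM, within 30 nM to 300 nM.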

Compound 3, antagonist equilibrium constant: 125 nM
For compound 3 the middle estimate is 1.4-fold (0.14 log units) below the measured one; the measured number falls inside the stated range.
By their numbers in this assay, from the lowest: compound 1; then compounds 2 and 3 (each within the scatter of the next).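

The exchange of methylsulfanyl for nitro on this aromatic carbon, meta to a large group, leaves the number in this assay unchanged within the scatter (a 1.0-fold higher number from compound 2 to compound 3 (0.02 log units; within the scatter)), even though carbon and sulfur give way to nitrogen and oxygen. Nitro in place of hydrogen gives a modest rise (a 4.6-fold higher number from compound 1 to compound 3 (0.67 log units; beyond the scatter)), which matches the step for methylsulfanyl in place of hydrogen (a 4.5-fold higher number from compound 1 to compound 2 (0.65 log units; beyond the scatter)), so among these three compounds both substituents stand on the same side of the unsubstituted compound 1, with none going against this. No measurement is available that accounts for the shared rise or for the absence of a difference between the two substituents.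

As far as these compounds go, it remains open whether the rise comes with any group at this place or only with these two, and an amine, a fluorine atom or a methyl group there would bear on that. From the compounds shown here alone, it also remains open whether nitro or methylsulfanyl on another carbon of the same ring would give a step of similar size.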